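Chloro in place of nitro in the series

The source may hold more compounds than are shown below. What is called first, only, known or untested is meant among the compounds shown, and "the series" means these compounds.

- compound 1 `O=[N+]([O-])c1cccc(-c2nn(-c3ccccc3)cc2C(Nc2nc3ccccc3s2)c2c(O)ccc3ccccc23)c1`: 32000 nM
- compound 2 `COc1ccc2nc(NC(c3cn(-c4ccccc4)nc3-c3cccc([N+](=O)[O-])c3)c3c(O)ccc4ccccc34)sc2c1`: 52200 nM
- compound 3 `O=[N+]([O-])c1cccc(-c2nn(-c3ccccc3)cc2C(Nc2nc3ccc(Cl)cc3s2)c2c(O)ccc3ccccc23)c1`: 42500 nM

In a functional assay on A549 cells (Homo sapiens) for antiproliferative activity, read by MTT assay, with a stated time of 48 h (on this read-out higher numbers stand for weaker inhibition and lower numbers for stronger inhibition), compound 3 gives 42500 nM and cannot be separated from the other two compounds: a 1.3-fold higher number from compound 1 to compound 3 (0.12 log units; within the scatter) and a 1.2-fold lower number from compound 2 to compound 3 (0.09 log units; within the scatter). The remaining measured step, a 1.6-fold higher number from compound 1 to compound 2 (0.21 log units; within the scatter), is equally small.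

Compound 4 `Oc1ccc2ccccc2c1C(Nc1nc2ccc(Cl)cc2s1)c1cn(-c2ccccc2)nc1-c1cccc(Cl)c1` differs by chloro in place of nitro on an aromatic carbon. Among the measured compounds shown here, no measured step touches this group, so the evidence is indirect, and the steps above show only a flat series. No change beyond the scatter is expected, and the estimated step is a 1.1-fold lower number from compound 3 to compound 4 (0.03 log units; within the scatter). For compound 4 the expected value is 40000 nM, with an estimated range of 18000 nM to 85000 nM.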

Compound 4, half-maximal inhibitory concentration: 33300 nM
The estimate for compound 4 lay 1.2-fold (0.08 log units) above the measured number; low and high end bracket the measured number.
By their numbers in this assay, from the lowest: compounds 1, 4, 3 and 2 (each within the scatter of the next).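

In this assay, among the compounds shown here, the exchange of 3-nitrophenyl for 3-chlorophenyl gives a 1.3-fold lower number from compound 3 to compound 4 (0.11 log units; within the scatter) and is the first measured change at this place on the shared core. Nitro, with its hydrogen-bond acceptors, can therefore give way to chloro, which has none, with no change beyond the scatter, and the flat picture now covers a second place. Nothing measured here bears on why the numbers stay flat.

As far as these compounds go, whether an amine or a carboxylic acid at this aromatic carbon would also leave the number unchanged stays open. So does whether any change at this place can move the number beyond the scatter.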